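The source may hold more compounds than are shown below. What is called first, only, known or untested is meant among the compounds shown, and "the series" means these compounds.

Measured compounds in a functional assay on the whole organism (Abdomen, strain Swiss) for inhibition, with Mus musculus as the target, with stated times of 40 min and 25 min, at a dose of 100 umol/kg by the oral route; a higher number here means more inhibition at the dose given (going by the name of the read-out), a lower number less inhibition:
compound 1, `COc1cc(/C=N/NC(=O)c2cnccn2)ccc1O`: 47%
compound 2, `COc1ccc(/C=N/NC(=O)c2cnccn2)cc1OC`: 73.6%

Compound 2 stands highest of the two numbers in this assay; the nearest, compound 1, lies lower by a gap beyond the scatter. Among the measured compounds shown here, the one measured step, a number 26.6 percentage points higher from compound 1 to compound 2 (beyond the scatter), came with methyl in place of hydrogen on an oxygen on an aromatic ring, a modest gain.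

Compound 3, `COc1ccc(/C=N/NC(=O)c2cnccn2)cc1O`, is to be measured in this assay. Its difference from compound 2: hydrogen in place of methyl on an oxygen on an aromatic ring. For the measured compounds named here, this is the measured kind of change run backwards, though not at the same oxygen, so the single step from compound 1 to compound 2 is the only guide, and it points to a loss of similar size. The step is therefore expected to be downward and beyond the scatter, estimated at a number 21.6 percentage points lower from compound 2 to compound 3 (beyond the scatter). Going by the values given here, compound 3 is expected to give about 52% in this assay, with a range from 35% to 70%; the width of that range reflects that only one pair of compounds supports the expectation.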

Compound 3, a percentage reported as inhibition, in the whole organism at one dose (the size of the read-out at that dose, not a potency): 64.8%
The estimate for compound 3 lay 12.8 percentage points below the measured number; measured number inside the range.
By their numbers in this assay, from the lowest: compound 1; then compounds 3 and 2 (each within the scatter of the next).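

In this assay, methoxy to hydroxy at this oxygen on the aromatic ring gives a number 8.8 percentage points lower from compound 2 to compound 3 (within the scatter), so this assay does not separate compound 2 from compound 3, and the methyl at this position is not needed to keep the inhibition seen with compound 2. The earlier step, a number 26.6 percentage points higher from compound 1 to compound 2 (beyond the scatter), also puts methyl in place of hydrogen on an oxygen on the aromatic ring, but at a different oxygen, so across these two steps the same kind of change reads differently depending on the oxygen that carries it, one beyond the scatter and the other within it. No measurement in hand explains this difference between the two oxygens.

The compounds shown leave open how an ethoxy group, a longer alkoxy chain or an amine would read at this position in this assay. Each number is also a reading at a single dose, so whether compound 2 and compound 3 would stay together at other doses remains an open question.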